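Swapping a methylphenyl for a methylsulfonylphenyl on a shared core

The source may hold more compounds than are shown below. What is called first, only, known or untested is meant among the compounds shown, and "the series" means these compounds.

Measured so far:
- compound 1, `NC(COCc1ccccc1)c1cc(F)ccc1N1CCN(C(=O)CCc2ccc(Cl)cc2Cl)CC1`: 1000 nM
- compound 2, `Cc1cccc(CCC(=O)N2CCN(c3ccc(C(F)(F)F)cc3[C@@H](N)CC(C)C)CC2)c1`: 2100 nM

Of the compounds shown here, two have been measured in an assay on HEK293 cells for displacement of a labelled ligand from Melanocortin receptor 4 (Homo sapiens); on this read-out lower numbers stand for stronger inhibition and higher numbers for weaker inhibition. Compound 1 gives 1000 nM and compound 2 gives 2100 nM, so compound 2 has the higher of the two numbers, a gap that lies beyond the usual scatter. Compound 3, `CC(C)C[C@H](N)c1cc(C(F)(F)F)ccc1N1CCN(C(=O)CCc2ccc(S(C)(=O)=O)cc2)CC1`, has not yet been measured; it shares the core of compound 2 and differs from it in a single group: 4-(methylsulfonyl)phenyl in place of 3-methylphenyl on a saturated chain carbon, two bonds along the chain from a carbonyl carbon. Within the data shown here, no measured pair shows this kind of exchange, so there is no direct step to lean on; compound 1 carries a different amine arm and a different ring and cannot serve as a guide. On that basis the change is expected to shift this assay by no more than the scatter, with a slight lean toward a higher number. Compound 3 is therefore estimated at 2500 nM, within 700 nM to 9000 nM, a step of a 1.2-fold higher number from compound 2 to compound 3 (0.08 log units; within the scatter) that is expected, not known.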

Compound 3, inhibition constant: 4900 nM
Estimate against measurement, compound 3: 2.0-fold (0.29 log units) below, within the range that was stated.
By their numbers in this assay, from the lowest: compound 1; then compound 2; then compound 3.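

In this assay, among these compounds, placing 4-(methylsulfonyl)phenyl in place of 3-methylphenyl on a saturated chain carbon, two bonds along the chain from a carbonyl carbon, gives a 2.3-fold higher number from compound 2 to compound 3 (0.37 log units; beyond the scatter), a modest step but the first single-place comparison here. It shows that the number responds to the group at this position, with the sulfone-bearing ring giving the weaker inhibition of this pair. The exchange alters both the substituent and its place on the ring, and nothing available explains the shift.

The two effects remain tangled: 4-methylphenyl or 3-(methylsulfonyl)phenyl at this position would help separate the substituent from its placement. From the compounds shown here alone, it also remains open how other groups on this ring, such as a carboxylic acid or an amine, would read.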